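The compounds below may be only part of what the source reports. "The series", "measured", "known", "first", "only" and "open" are said of these compounds alone.

Measured compounds:
- Compound 1, `CC1CCN(C2CCN(S(=O)(=O)c3cccc(-c4ccccc4F)c3)CC2)CC1`: 10 nM
- Compound 2, `COc1ccc(-c2ccccc2S(=O)(=O)N2CCC(N3CCC(C)CC3)CC2)cc1`: 1000 nM
- Compound 3, `CC1CCN(C2CCN(S(=O)(=O)c3ccc(Cl)c4ccccc34)CC2)CC1`: 0.1 nM

In a functional assay on DLD-1 cells (Homo sapiens) for antiproliferative activity, read by CellTiter-Glo, with a stated time of 72 h (on this read-out lower numbers stand for stronger inhibition and higher numbers for weaker inhibition), compound 1 gives 10 nM, which places it second highest of the three numbers: compound 2 gives 1000 nM, a higher number, and compound 3 gives 0.1 nM, a lower one, both gaps beyond the usual scatter. For the measured compounds named here, the compound not yet measured, compound 4 `Cc1ccc(-c2cccc(S(=O)(=O)N3CCC(N4CCC(C)CC4)CC3)c2)cc1`, keeps the shared core of compound 1 and changes only one group: 4-methylphenyl in place of 2-fluorophenyl on an aromatic carbon. Both groups are single six-membered aromatic rings of the same size, so the change is a swap of one ring for a closely related one at the same place. Going by the values given here, no measured pair shows this exact swap, so there is no directly comparable step to lean on. Against that background, only a small step is expected in this assay, most likely no change beyond the scatter, with a slight lean toward a higher number. Compound 4 is therefore estimated at 20 nM, within a range from 3 nM to 150 nM, which means an expected step of a 2.0-fold higher number from compound 1 to compound 4 (0.30 log units; within the scatter).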

Compound 4, half-maximal inhibitory concentration: 11 nM
Compound 4: the middle estimate sits 1.8-fold (0.26 log units) above what was measured, within the range that was stated.
By their numbers in this assay, from the lowest: compound 3; then compounds 1 and 4 (each within the scatter of the next); then compound 2.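

In this assay, placing 4-methylphenyl in place of 2-fluorophenyl on an aromatic carbon gives a 1.1-fold higher number from compound 1 to compound 4 (0.04 log units; within the scatter), a step within the usual scatter, so the two compounds cannot be told apart. This is the first pair shown that differs in one place, and it indicates that, at this position, this swap between two single six-membered carbon rings leaves the read-out unmoved, even though a fluorine leaves and a methyl enters. Nothing measured here offers an explanation for this match.

The compounds shown leave open how this position responds to something other than a substituted phenyl ring, such as a pyridyl ring, an amine or a carboxylic acid. They also leave open whether an unsubstituted phenyl ring would read the same as these two groups.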